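The source may report more compounds than this note shows. Statements on the series, on what has been measured and on what is new or still open speak of the compounds shown alone.

Measured so far in an assay on isolated protein for inhibition of leukotriene B4 receptor 1 (Homo sapiens), tested at 10 uM; on this read-out lower numbers stand for less inhibition and higher numbers for more inhibition at the one concentration tested (going by the name of the read-out):
Compound 1 `CCc1cc(C(C)=O)c(O)cc1OCCCCC(C)(C)C#N` gives 79%.
Compound 2 `CCc1cc(C(C)=O)c(O)cc1OCCCC(C)(C)C(=O)O` gives 89%.
Compound 3 `CCc1cc(C(C)=O)c(O)cc1OCCCCCCC(=O)N(C)C` gives 100%.

Compound 3 stands highest of the three in this assay, with a number 11 percentage points higher from compound 2 to compound 3 (beyond the scatter) and a number 21 percentage points higher from compound 1 to compound 3 (beyond the scatter), while a number 10 percentage points higher from compound 1 to compound 2 (within the scatter). Compound 4 `CCc1cc(C(C)=O)c(O)cc1OCCCCCCc1nnn[nH]1` differs from compound 3 in one place: 1H-tetrazol-5-yl in place of dimethylcarbamoyl on a saturated chain carbon, six bonds along the chain from an oxygen on an aromatic ring. For the measured compounds named here, no measured step swaps the terminal group at this chain position for a ring, so the steps into compound 3 bear on it only loosely; both changed the end group and moved the number upward, but from lower starting points. Compound 3 already sits at the top of the read-out, so no further rise is expected, and a modest fall within or near the scatter is estimated, a number 8 percentage points lower from compound 3 to compound 4 (within the scatter). Compound 4 is therefore expected at 92%, between 78% and 100%.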

Compound 4, a percentage reported as inhibition, at one concentration (the size of the read-out at that concentration, not a potency): 91%
The estimate for compound 4 lay 1 percentage points above the measured number, within the range that was stated.
By their numbers in this assay, from the lowest: compounds 1, 2, 4 and 3 (each within the scatter of the next, the first and the last beyond it).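

In this assay, a ring at the chain end holds up: 1H-tetrazol-5-yl in place of dimethylcarbamoyl gives a number 9 percentage points lower from compound 3 to compound 4 (within the scatter), so this position accepts a five-membered aromatic ring with 4 hetero atoms as well as an open-chain amide. The tetrazole also gives a number 2 percentage points higher from compound 2 to compound 4 (within the scatter), while a number 12 percentage points higher from compound 1 to compound 4 (beyond the scatter), which leaves only the nitrile-bearing compound 1 apart from it. Nothing available explains these numbers.

Open, going by these compounds, is whether an unbranched carboxylic acid or a primary amine at this chain end reads the same. On these data alone, a longer chain carrying the tetrazole is equally open.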